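The compounds below may be only part of what the source reports. "The series", "measured", "known", "first", "only" and "open" are said of these compounds alone.

Working notes on the series.

Three compounds share one core. Compound 1 `CN1C(=O)C2=C(C1=O)N(CC(=O)Nc1ccc(-c3ccncc3)cc1)CCC2` carries a pyridin-4-yl and in an assay on cells for inhibition of Protein-serine O-palmitoleoyltransferase porcupine (Homo sapiens), read by reporter gene assay (on this read-out lower numbers stand for stronger inhibition and higher numbers for weaker inhibition), compound 1 gives 72 nM. Within the data shown here, compound 2 `CN1C(=O)C2=C(C1=O)N(CC(=O)Nc1ccc(-c3cccnc3)cc1)CCC2` carries a pyridin-3-yl on the same phenyl, and in this assay compound 2 gives 8 nM; the single one-place step measured so far is a 9.0-fold lower number from compound 1 to compound 2 (0.95 log units; beyond the scatter). Compound 3 `CN1C(=O)C2=C(C1=O)N(CC(=O)Nc1ccc(-c3cccnc3)nn1)CCC2` keeps the pyridin-3-yl but on a pyridazine in place of the phenyl, and in this assay compound 3 gives 29 nM, the second highest of the three numbers, between compound 1 and compound 2.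

Compound 4 `Cc1ccc(-c2ccc(NC(=O)CN3CCCC4=C3C(=O)N(C)C4=O)nn2)cn1` differs from compound 3 by methyl in place of hydrogen on an aromatic carbon, read one bond further out as pyridin-3-yl to 6-methylpyridin-3-yl. Among the measured compounds shown here, no measured step bears on this change: the only step in hand, from compound 1 to compound 2, moves the ring nitrogen and says nothing about a methyl. For the measured compounds named here, with no precedent, the expected step of a 1.2-fold lower number from compound 3 to compound 4 (0.06 log units; within the scatter) in this assay is none beyond the scatter. Compound 4 is therefore estimated at 25 nM, with a range from 8 nM to 80 nM.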

Compound 4, half-maximal inhibitory concentration in the Protein-serine O-palmitoleoyltransferase porcupine assay: 29 nM
Compound 4: the middle estimate sits 1.2-fold (0.06 log units) below what was measured, and the stated range covers the measured number.
By their numbers in the Protein-serine O-palmitoleoyltransferase porcupine assay, from the lowest: compound 2; then compounds 3 and 4 (each within the scatter of the next); then compound 1.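

The earlier compounds shown here carry only hydrogen at this place on the pyridin-3-yl; in the Protein-serine O-palmitoleoyltransferase porcupine assay methyl in place of hydrogen on an aromatic carbon, next to the ring nitrogen, gives no change at the digits printed from compound 3 to compound 4 (within the scatter) and so leaves the number where it stood. In a physicochemical assay for solubility, measured as thermodynamic solubility, at pH 4 (a higher number here means a more soluble compound, a lower number a less soluble compound), compound 3 gives 13.9 ug/mL as its measured solubility. In the physicochemical assay compound 4 gives > 194 ug/mL as its solubility, which is a limit of the assay and not a number.

From the compounds shown here alone, how far the solubility of compound 4 lies past that limit stays open: the limit of > 194 ug/mL in the physicochemical assay, at which 1 of the 2 values shown sits. Also open, going by these compounds, is whether a longer chain such as ethyl, or an amine, at the same place keeps the number in the Protein-serine O-palmitoleoyltransferase porcupine assay and whether methyl does the same on the phenyl of compound 2.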